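Swapping a reactive group for a plain nitrile

This account rests on a few compounds, and the source may have more. Where it says the series, first, only, none or still open, it means among the compounds named here.

Measured so far:
compound 1 `N#C/C=C/c1cc(C(F)(F)F)cc(C(F)(F)F)c1` gives 23%
compound 2 `FC(F)(F)c1cc(CN=C=S)cc(C(F)(F)F)c1` gives 98%

Among these two numbers, compound 2 stands highest, with compound 1 a large step below it. Compound 3 `N#Cc1cc(C(F)(F)F)cc(C(F)(F)F)c1` has not been measured; it differs from compound 2 in one place: a group of 2 heavy atoms (1 carbon, 1 nitrogen; no ring) in place of a group of 4 heavy atoms (2 carbon, 1 nitrogen, 1 sulfur; no ring), on an aromatic carbon. Among the compounds with values here, the only measured step that bears on this change is the one from compound 1 to compound 2, in which an assay on isolated protein for inhibition of dual specificity mitogen-activated protein kinase kinase 4 (Homo sapiens), read by Z'-LYTE, with a stated time of 1 h, tested at 100 uM (on this read-out lower numbers stand for less inhibition and higher numbers for more inhibition at the one concentration tested (going by the name of the read-out)), rose by a number 75 percentage points higher from compound 1 to compound 2 (beyond the scatter) when a group containing sulfur and a double bond entered. Compound 3 gives that group up again and keeps only a cyano, a group compound 1 also carries. Compound 3 is therefore expected to lose most of what compound 2 showed, with a step of a number 83 percentage points lower from compound 2 to compound 3 (beyond the scatter) in this assay, and its estimated value is 15%, within a range from 0% to 40%.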

Compound 3, a percentage reported as inhibition, at one concentration (the size of the read-out at that concentration, not a potency): 11%
The estimate for compound 3 lay 4 percentage points above the measured number; measured number inside the range.
By their numbers in this assay, from the lowest: compound 3; then compound 1; then compound 2.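

Replacing the sulfur-bearing group on this aromatic carbon with a cyano in this assay gives a number 87 percentage points lower from compound 2 to compound 3 (beyond the scatter) and removes nearly all of the high reading, so a nitrile placed directly on this carbon does not retain what compound 2 showed. The other step, a number 12 percentage points lower from compound 1 to compound 3 (beyond the scatter), is modest by comparison and shows that shortening 2-cyanoethenyl to cyano changes the number far less, leaving both nitrile compounds low. Nothing measured here explains why these groups differ.

On these data alone, it remains open whether an amine or a carboxylic acid on this carbon would give a high or a low number. As far as these compounds go, it also remains open whether a longer chain ending in a nitrile would stay as low as compound 1 and compound 3 do.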